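This account rests on a few compounds, and the source may have more. Where it says the series, first, only, none or still open, it means among the compounds named here.

Measured compounds:
compound 1 `COc1ccc2sc(NC(=O)c3ccc(C(F)(F)F)cc3)nc2c1` — > 10 ug/mL
compound 2 `COc1ccc(C(=O)Nc2nc3c(OC)cccc3s2)cc1` — 3.46 ug/mL

Of the compounds shown here, two have been tested in a functional assay on NUGC-3 cells (Homo sapiens) for antiproliferative activity, read by sulforhodamine B assay; on this read-out lower numbers stand for stronger inhibition of growth and higher numbers for weaker inhibition of growth. Compound 1 `COc1ccc2sc(NC(=O)c3ccc(C(F)(F)F)cc3)nc2c1` reaches only a limit of the assay, > 10 ug/mL, so no number is known for it, a situation described by the limit of > 10 ug/mL in this assay, at which 1 of the 2 values shown sits. Among the compounds with values here, compound 2 `COc1ccc(C(=O)Nc2nc3c(OC)cccc3s2)cc1` gives 3.46 ug/mL, the only actual number among the two values shown, so it stands alone rather than ranking against anything. Compound 3 `COc1cccc2sc(NC(=O)c3ccc(C#N)cc3)nc12` is not yet measured. It differs from compound 2 in one place: cyano in place of methoxy on an aromatic carbon. Within the data shown here, both groups are of the same size and neither donates a hydrogen bond, yet there is no measured step between two compounds that would tell how such a swap plays out in this assay; with only a limit and a single number on hand, any expectation is loosely held. The step from compound 2 to compound 3 is expected to be modest, a 1.4-fold higher number from compound 2 to compound 3 (0.16 log units; within the scatter), with a real chance that it runs past the limit of the assay. The estimate for compound 3 is therefore 5 ug/mL, within a range from 1.5 ug/mL to 15 ug/mL.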

Compound 3, concentration for 50% growth inhibition: > 10 ug/mL
Compound 3: no number, only a limit; the forecaster's own chance of this, stated with the estimate: 40%; middle value at least 2.0-fold (0.30 log units) away from the limit.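

Within the data shown here, replacing methoxy with cyano on the aromatic carbon para to a large group is the first change here that can be read as a step, and in this assay it gives an at least 2.8-fold higher number from compound 2 to compound 3 (0.46 log units; beyond the scatter). At this position the two groups are therefore not interchangeable, even though each brings the same count of heavy atoms and hydrogen-bond acceptors. Compound 3 reaches only a limit, so the step gives a minimum and its full size remains unknown: the limit of > 10 ug/mL in this assay, at which 2 of the 3 values shown sit.

Among these compounds, compound 2 holds the only actual number, and compound 1 differs from it in more than one place, so it is still open whether methoxy is special here or cyano alone is poorly tolerated. An amine or a hydroxyl group on the same aromatic carbon, with the rest of compound 2 unchanged, would help separate these two readings.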